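The source may report more compounds than this note shows. Statements on the series, on what has been measured and on what is new or still open speak of the compounds shown alone.

Compound 3 `N#CC1=C(N)Oc2c(N)cc3nc4ccccc4nc3c2C12C(=O)N(Cc1cnnn1-c1ccc([N+](=O)[O-])cc1)c1ccccc12` stands among three related compounds examined in a functional assay on MCF7 cells (Homo sapiens) for antiproliferative activity, read by MTT assay, with a stated time of 48 h; on this read-out higher numbers stand for weaker inhibition and lower numbers for stronger inhibition. In this assay compound 3 gives > 50000 nM, which is a limit of the assay and not a number. Compound 1 `Cc1ccccc1-n1nncc1CN1C(=O)C2(C(C#N)=C(N)Oc3c2c2nc4ccccc4nc2c2ccccc32)c2ccccc21` gives > 50000 nM in this assay, again only a limit. Compound 2 `N#CC1=C(N)Oc2c(c3nc4ccccc4nc3c3ccccc23)C12C(=O)N(Cc1cnnn1-c1ccc(Cl)cc1)c1ccccc12` gives > 50000 nM in this assay, also a limit. Among the measured compounds shown here, the one measured step, a step that the two limits leave unreadable from compound 1 to compound 2, cannot be read in size, since both ends rest on (the limit of > 50000 nM in this assay, at which 3 of the 3 values shown sit). Compound 4 `Cc1cc(C)c(-n2nncc2CN2C(=O)C3(C(C#N)=C(N)Oc4c(N)cc5nc6ccccc6nc5c43)c3ccccc32)c(C)c1` is the member not yet measured; it differs from compound 3 at a single site: 2,4,6-trimethylphenyl in place of 4-nitrophenyl on an aromatic nitrogen. For the measured compounds named here, no measured step bears directly on this exchange on the aromatic nitrogen of the five-membered aromatic ring with 3 nitrogen, and every value shown so far sits at the limit of > 50000 nM in this assay, at which 3 of the 3 values shown sit. On that basis compound 4 is expected to behave like its relatives, with an estimated 50000 nM in this assay, spanning 20000 nM to 100000 nM. The step of a number no higher from compound 3 to compound 4 (the limit leaves the size open) is therefore expected to be none beyond the scatter, most likely reported once more only as a limit.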

Compound 4, half-maximal inhibitory concentration: > 50000 nM
Compound 4 ended at the assay's limit; the forecaster's own chance of this, stated with the estimate: 80%; the middle value sits exactly at the limit.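

Compound 3 and compound 4 both rest on a limit of the assay and not a number in this assay, so no step can be read for this exchange of 4-nitrophenyl for 2,4,6-trimethylphenyl: the limit of > 50000 nM in this assay, at which 4 of the 4 values shown sit. The compounds shown leave open whether any group on this aromatic nitrogen would give a readable value in this assay.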